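Pyridin-4-yl replacing 3-fluorophenyl on the aromatic nitrogen

This account rests on a few compounds, and the source may have more. Where it says the series, first, only, none or still open, it means among the compounds named here.

The series shares one core; compound 2 is `C[C@H](Nc1ncnc2[nH]cnc12)c1nn(-c2cccc(F)c2)c2cc(F)ccc12`, compound 1 is `C[C@H](Nc1ncnc2[nH]cnc12)c1nn(-c2cccnc2)c2ccc(F)cc12` and compound 3 is `C[C@H](Nc1nc(N)nc(N)c1C#N)c1nn(-c2cccc(S(C)(=O)=O)c2)c2cc(Cl)ccc12`. In a functional assay on HepG2 cells (Homo sapiens) for inhibition, read by sulforhodamine B assay, with a stated time of 72 h, tested at 10 uM (a lower number here means less inhibition, a higher number more inhibition at the concentration tested (going by the name of the read-out)), compound 2 gives 33%, the second highest of the three numbers. Compound 3 gives 56%, a number beyond the scatter above compound 2, and compound 1 gives 8%, beyond the scatter below it. Compounds 1 and 3 differ from compound 2 in more than one place, so only their values, not single steps, can be read.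

Compound 4 is `C[C@H](Nc1ncnc2[nH]cnc12)c1nn(-c2ccncc2)c2cc(F)ccc12`. It differs from compound 2 by pyridin-4-yl in place of 3-fluorophenyl on an aromatic nitrogen. Going by the values given here, no pair of measured compounds isolates this change, so its size is not known from the data. The expectation for a number 11 percentage points lower from compound 2 to compound 4 (beyond the scatter) is a small decrease, perhaps at the edge of the scatter, with no firm support either way. Compound 4 is expected to give about 22%, within a range from 5% to 40%.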

Compound 4, a percentage reported as inhibition, at one concentration (the size of the read-out at that concentration, not a potency): 47%
Compound 4: middle estimate off by 25 percentage points, on the low side, and the stated range ends below it.
By their numbers in this assay, from the lowest: compound 1; then compound 2; then compounds 4 and 3 (each within the scatter of the next).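

Going by these compounds alone, this is the first single-change step: in this assay, pyridin-4-yl in place of 3-fluorophenyl on the aromatic nitrogen gives a number 14 percentage points higher from compound 2 to compound 4 (beyond the scatter), a modest gain in inhibition at the one concentration tested. Inhibition at this position therefore does not depend on keeping the 3-fluorophenyl group, and a six-membered aromatic ring with a ring nitrogen is accepted on the core of compound 2. Nothing available bears on why the number rises.

Within the data shown here, still open is whether pyridin-3-yl, seen only on the differently substituted core of compound 1, would match pyridin-4-yl on the core of compound 2. Also open, from the compounds shown here alone, is how a non-aromatic group on the same nitrogen, such as a piperidine ring or a simple methyl, would compare.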